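Nitro in place of chloro: notes toward compound 3

This account rests on a few compounds, and the source may have more. Where it says the series, first, only, none or still open, it means among the compounds named here.

Two members of the series have a number in a functional assay on CHO cells for agonist activity at adenosine receptor A1 (Homo sapiens), read by fluorescence and ERK phosphorylation, with stated times of 30 min and 1.5 h, tested at 10 uM; a lower number here means a weaker effect, a higher number a stronger effect of the compound at the concentration tested. Compound 1 `Nc1scc(-c2cccc([N+](=O)[O-])c2)c1C(=O)c1ccccc1` gives 50% in this assay. Compound 2 `Nc1scc(-c2cccc(Cl)c2)c1C(=O)c1ccc(Cl)cc1` gives 75% in this assay, which is the higher of the two numbers, and the gap to compound 1 lies beyond the scatter of repeated measurements.

Compound 3 `Nc1scc(-c2cccc([N+](=O)[O-])c2)c1C(=O)c1ccc(Cl)cc1` has not been measured yet. It differs from compound 2 in one place: nitro in place of chloro on an aromatic carbon. The nitro group at this place is the same group that compound 1 carries, while the chloro on the other ring of compound 2 is kept. Going by the values given here, compound 3 therefore sits between the two measured compounds in its substitution, and no single-point step between measured compounds is available to calibrate the exchange.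

The expectation is a moderate downward step in this assay from compound 2, of about a number 15 percentage points lower from compound 2 to compound 3 (beyond the scatter), which may or may not exceed the scatter. On that basis compound 3 is estimated at 60% in this assay, with a likely range from 40% to 80%.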

Compound 3, a percentage reported as activity, at one concentration (the size of the read-out at that concentration, not a potency): 42%
Compound 3: middle estimate off by 18 percentage points, on the high side; measured number inside the range.
By their numbers in this assay, from the lowest: compounds 3 and 1 (each within the scatter of the next); then compound 2.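

In this assay, going by these compounds alone, the exchange of nitro for chloro on an aromatic carbon, meta to a large group, gives the first single-place reading at this position: a large step, a number 33 percentage points lower from compound 2 to compound 3 (beyond the scatter) in the read-out. Within the data shown here, with nitro kept, chloro in place of hydrogen on the other ring gives a number 8 percentage points lower from compound 1 to compound 3 (within the scatter) and so does not separate the two compounds, which leaves the exchange at this position as the only single-place step here that lies beyond the scatter. Nothing at hand bears on why this exchange lowers the read-out.

The compounds shown do not tell whether the exchange gives a step of the same size when hydrogen replaces the chloro on the other ring, or whether that chloro has any effect when chloro rather than nitro occupies this position. They also leave open how an amine, a carboxylic acid or a nitrile at this position would read, and, with only a single tested concentration, whether the step reflects a change in potency or in the size of the effect.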